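This account rests on a few compounds, and the source may have more. Where it says the series, first, only, none or still open, it means among the compounds named here.

Measured so far in an ADME assay on liver (Mesocricetus auratus) for metabolic stability, using microsomes (on this read-out higher numbers stand for fast clearance and lower numbers for slow clearance), are three compounds:

- Compound 1 `O=C(NCc1ccccc1)Nc1[nH]nc(-c2ccccn2)c1Cl` gives > 400 mL.min-1.g-1 (a limit of the assay, not a number)
- Compound 2 `N#Cc1ccc(OC2CCN(C(=O)Nc3cc(-c4ccccn4)n[nH]3)CC2)cc1` gives 30.8 mL.min-1.g-1 (a number)
- Compound 3 `O=C(Nc1cc(-c2ccccn2)n[nH]1)N1CCC(c2ccc(F)cc2)CC1` gives 272 mL.min-1.g-1 (a number)

Compound 3 holds the higher of the two actual numbers. Still unmeasured is compound 4 `O=C(Nc1cc(-c2ccccn2)n[nH]1)N1CCC(c2ccc(Cl)cc2)CC1` and its difference from compound 3 is small: chloro in place of fluoro on an aromatic carbon.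

Going by the values given here, the only measured step is an 8.8-fold higher number from compound 2 to compound 3 (0.95 log units; beyond the scatter) and it exchanges a whole group, 4-fluorophenyl in place of 4-cyanophenoxy, so it gives no direct size for this swap of one atom. A far smaller change is expected here, one that stays within the scatter. The anchor is compound 3, which gives 272 mL.min-1.g-1. The expected step is a 1.1-fold higher number from compound 3 to compound 4 (0.04 log units; within the scatter) and no clear direction is assumed. Compound 1 marks the limit of > 400 mL.min-1.g-1 in this assay, at which 1 of the 3 values shown sits, so compound 4 could also be reported only as a limit. Compound 4 is estimated at 300 mL.min-1.g-1 (expected range 150 mL.min-1.g-1 to 550 mL.min-1.g-1).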

Compound 4, intrinsic clearance in microsomes: 43.8 mL.min-1.g-1
Compound 4: middle estimate off by 6.8-fold (0.84 log units), on the high side, outside the stated range (below it).
By their numbers in this assay, from the lowest: compounds 2 and 4 (each within the scatter of the next); then compound 3. At a limit, above all of these: compound 1.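

In this assay, chloro in place of fluoro on an aromatic carbon, para to a large group, changes a single atom and still gives a 6.2-fold lower number from compound 3 to compound 4 (0.79 log units; beyond the scatter), so the read-out in this series can respond strongly to the one atom at this position. The 4-chlorophenyl group and the 4-cyanophenoxy group on the saturated ring carbon give a 1.4-fold higher number from compound 2 to compound 4 (0.15 log units; within the scatter), so the wide gap seen with 4-fluorophenyl does not hold for every aryl group in that place. The measurements shown give no cause for the difference between chloro and fluoro here.

From the compounds shown here alone, it remains open whether methyl, methoxy or trifluoromethyl at this position would read like chloro or like fluoro. Also open, going by these compounds, is whether an unsubstituted phenyl ring would fall with either halogen.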